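Swapping a Small Ring on an Ether-Linked Side Chain

The compounds below may be only part of what the source reports. "The series", "measured", "known", "first", "only" and "open" are said of these compounds alone.

Compound 1, `CC1CC1COc1cccc2ccc(N)nc12`, was tested in an assay on cells with melanin-concentrating hormone receptor 1 (Homo sapiens) as the target, read by radioligand binding; on this read-out lower numbers stand for stronger inhibition and higher numbers for weaker inhibition. In this assay compound 1 gives 1640 nM, the only plain number among the results shown. Compound 2, `CC(CC(C)(C)C)Oc1cccc2ccc(N3CCCC3)nc12`, gives in this assay > 2000 nM, which is a limit of the assay rather than a number, as recorded in the limit of > 2000 nM in this assay, at which 1 of the 2 values shown sits.

Compound 3, `Nc1ccc2cccc(OCC3CCC3)c2n1`, has not yet been measured. It differs from compound 1 by cyclobutyl in place of 2-methylcyclopropyl on a saturated chain carbon bound to an oxygen on an aromatic ring; the same difference, cut one bond further out, reads (2-methylcyclopropyl)methyl to cyclobutylmethyl. Among the measured compounds shown here, no step between two measured compounds is available here, so there is no measured reference for how large such a change might be. The step is expected to stay within the usual scatter, with no clear direction: a 1.1-fold lower number from compound 1 to compound 3 (0.04 log units; within the scatter) in this assay. Compound 3 is therefore expected to give about 1500 nM in this assay, with a likely range from 600 nM to 4000 nM.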

Compound 3, half-maximal inhibitory concentration: 432 nM
Beside the measured number, compound 3's estimate is 3.5-fold (0.54 log units) above it; measured number below the stated range.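

In this assay, cyclobutyl in place of 2-methylcyclopropyl on a saturated chain carbon bound to an oxygen on an aromatic ring gives a 3.8-fold lower number from compound 1 to compound 3 (0.58 log units; beyond the scatter). Among the compounds shown here, the two groups hold the same atoms, joined differently, so at this place a rearrangement alone, with no atom gained or lost, is enough to move the number beyond the usual scatter, something the earlier compounds could not show because they offered no step at all. Why the ring with four members gives the lower number cannot be said, as nothing measured here bears on the cause.

The compounds shown leave open what a larger ring such as cyclopentyl, or an open chain such as butyl, would do at this same place. Also open, on these data alone, is whether this exchange would give a similar step on a core carrying a different amine.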